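Chloro in Place of Trifluoromethyl on Compound 2

A few compounds are considered here, and "the series" means these few. Any claim that something is new, unique, unknown or untested is made for them only; others in the source may bear on it.

Of the compounds shown here, two have so far been tested in a functional assay on UoC-B1 cells (Homo sapiens) for antiproliferative activity, with a stated time of 72 h; on this read-out higher numbers stand for an effect only at larger amounts of compound and lower numbers for an effect already at smaller amounts. Compound 1 `COc1cc(OC)c2c(=O)cc(C(=O)Nc3ccc4oc(-c5ccc(F)cc5)nc4c3)[nH]c2c1` returned only a limit of the assay, > 36700 nM, and no number stands for it. Compound 2 `COC(=O)c1cc(=O)c2cc(NC(=O)Nc3ccc(Cl)c(C(F)(F)F)c3)ccc2[nH]1` likewise returned only a limit, > 6350 nM, so its place among the values shown is one of the two limit readings in this assay, as the limit of > 6350 nM in this assay, at which 1 of the 2 values shown sits, records. Compound 3 `COC(=O)c1cc(=O)c2cc(NC(=O)Nc3ccc(Cl)c(Cl)c3)ccc2[nH]1` has not yet been measured; it differs from compound 2 by chloro in place of trifluoromethyl on an aromatic carbon. Going by the values given here, no step between measured compounds exists against which to gauge this change. The expected step that the limit leaves unreadable from compound 2 to compound 3 is judged to stay within the scatter, with no direction favoured. Compound 3 is therefore estimated at 10000 nM, within a range from 3000 nM to 40000 nM, and a limit rather than a number is the likelier outcome.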

Compound 3, half-maximal effective concentration: > 6350 nM
Compound 3: a limit, no number (the forecaster's own chance of this, stated with the estimate: 70%); the middle value does not contradict the limit.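

In this assay, going by these compounds alone, compound 3, like compound 2, returned only a limit of the assay, so no step between them can be read: the limit of > 6350 nM in this assay, at which 2 of the 3 values shown sit. The compounds shown leave open whether chloro in place of trifluoromethyl on an aromatic carbon makes any difference to the read-out.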